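The compounds below may be only part of what the source reports. "The series", "measured", "known", "first", "only" and "open" are said of these compounds alone.

Compound 1 `C#CCSc1nc(Sc2nccs2)c(C#N)c(-c2ccc(Br)cc2)n1`: 10900 nM
Compound 2 `C#CCSc1nc(Sc2nc[nH]n2)c(C#N)c(-c2cc(OC)c(OC)c(OC)c2)n1`: > 20000 nM (a limit)
Compound 3 `C#CCSc1nc(Sc2nnnn2CCN(C)C)c(C#N)c(-c2cccc(Cl)c2)n1`: 5320 nM

In a functional assay on KYSE-70 cells for antiproliferative activity against KYSE-70 cell line (Homo sapiens), read by MTT assay, with a stated time of 72 h (a lower number here means a stronger inhibitor, a higher number a weaker inhibitor), only two of these three results are true numbers. Compound 1, at 10900 nM, holds the higher of the two, and the gap down to compound 3 at 5320 nM lies just beyond the scatter. Compound 2 reads > 20000 nM, which is a limit of the assay and not a number.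

Compound 4 `C#CCSc1nc(Sc2nccs2)c(C#N)c(-c2ccc(C)cc2)n1` keeps everything in compound 1 except one group: 4-bromophenyl becomes 4-methylphenyl, with methyl in place of bromo on an aromatic carbon. For the measured compounds named here, no measured pair here differs in one place only, so the data offer no direct guide to this swap. The counted change is small, and no step beyond the scatter is expected in this assay, starting from compound 1 at 10900 nM. The estimated change is a 1.1-fold higher number from compound 1 to compound 4 (0.06 log units; within the scatter). For compound 4 the expected value is 12500 nM, with an estimated range of 6000 nM to 20000 nM.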

Compound 4, half-maximal inhibitory concentration: 4300 nM
For compound 4 the middle estimate is 2.9-fold (0.46 log units) above the measured one, outside the stated range (below it).
By their numbers in this assay, from the lowest: compounds 4 and 3 (each within the scatter of the next); then compound 1. At a limit, above all of these: compound 2.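

For the compounds shown here, this is the only pair here that differs in one place, and it shows that this position, on an aromatic carbon of the phenyl ring, responds to a small exchange: in this assay, methyl in place of bromo gives a 2.5-fold lower number from compound 1 to compound 4 (0.40 log units; beyond the scatter). One heavy atom replaces one heavy atom, and no ring, hydrogen-bond donor, hydrogen-bond acceptor or net charge enters or leaves, so even a change this slight produces a modest step. Nothing measured here explains why the number moves in this direction.

As far as these compounds go, it remains open how other groups at this place, such as an amine or a carboxylic acid, would compare with methyl. From the compounds shown here alone, it is also open whether the same swap would give a similar step with the different sulfur-linked ring and side chain of compound 3.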